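Aryloxy for isobutyl on the shared core: solubility outlook

The source may report more compounds than this note shows. Statements on the series, on what has been measured and on what is new or still open speak of the compounds shown alone.

Three compounds of the series carry the shared core with a propylene-diamine side chain. In a physicochemical assay for solubility, with a stated time of 18 h, at pH 7.4 (on this read-out lower numbers stand for lower solubility and higher numbers for higher solubility), compound 1 `FC(F)(F)c1ccc(-c2ccc3c(NCCCNCc4ccco4)ccnc3c2)cc1` gives 32000 nM, compound 2 `CC(C)Cc1ccc2c(NCCCNCc3ccco3)ccnc2c1` gives 4200 nM and compound 3 `COc1cccc(Oc2ccc3c(NCCCNCc4cc(F)ccc4OC)ccnc3c2)c1` gives 14500 nM. Compound 2 stands lowest of the three numbers on this assay; its nearest neighbour is compound 3 and its furthest is compound 1, both beyond the scatter.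

The next step replaces the isobutyl of compound 2 by 3-(dimethylamino)phenoxy on the same aromatic carbon, giving compound 4 `CN(C)c1cccc(Oc2ccc3c(NCCCNCc4ccco4)ccnc3c2)c1`; counted out, the change is 3-(dimethylamino)phenoxy in place of isobutyl on an aromatic carbon.

Among the compounds with values here, one measured step bears on it: a 7.6-fold lower number from compound 1 to compound 2 (0.88 log units; beyond the scatter), where an aryl group gave way to isobutyl. Within the data shown here, compound 3, with an aryloxy group at that carbon, shows a higher number than compound 2, though its side chain also differs, so no single step links the two. Restoring an aromatic substituent is therefore expected to raise this assay, by a 3.8-fold higher number from compound 2 to compound 4 (0.58 log units; beyond the scatter), about the size of the step seen from compound 1 to compound 2 but reversed. Compound 4 is estimated at 16000 nM, with a range of 5000 nM to 45000 nM.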

Compound 4, solubility: 14500 nM
For compound 4 the middle estimate is 1.1-fold (0.04 log units) above the measured one; measured number inside the range.
By their numbers in this assay, from the lowest: compound 2; then compounds 3 and 4 (each within the scatter of the next); then compound 1.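

In this assay, with the furan-bearing side chain held constant, the change to 3-(dimethylamino)phenoxy at this aromatic carbon gives a 3.5-fold higher number from compound 2 to compound 4 (0.54 log units; beyond the scatter), so the isobutyl compound now sits below an aryloxy compound in a single-place comparison as well as below an aryl one. Against the 4-(trifluoromethyl)phenyl group, the same substituent gives a 2.2-fold lower number from compound 1 to compound 4 (0.34 log units; beyond the scatter), which places the three compounds on this side chain in the order compound 2, compound 4, compound 1, with every step beyond the scatter. Nothing in hand accounts for these differences.

The compounds shown do not separate the ether oxygen from the dimethylamino group, and a plain phenoxy or a 3-(dimethylamino)phenyl at this carbon would make that reading possible. As far as these compounds go, how a carboxylic acid on the same aromatic ring would place remains open.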